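Ring variation at the amide end of the series

A few compounds are considered here, and "the series" means these few. Any claim that something is new, unique, unknown or untested is made for them only; others in the source may bear on it.

The series shares one core and differs only at the amide end. Compound 1 `CC(C)=CCC/C(C)=C/CC/C(C)=C/CSC[C@H](NC(=O)CCCCCN1CCN(C)CC1)C(=O)NC1CC1` carries a cyclopropylamino group there, compound 2 `CC(C)=CCC/C(C)=C/CC/C(C)=C/CSC[C@H](NC(=O)CCCCCN1CCN(C)CC1)C(=O)NC1CCCC1` a cyclopentylamino group, and compound 3 `CC(C)=CCC/C(C)=C/CC/C(C)=C/CSC[C@H](NC(=O)CCCCCN1CCN(C)CC1)C(=O)N1CCCCC1` a piperidin-1-yl group. In a functional assay on MIA PaCa-2 cells (Homo sapiens) for cytotoxicity, read by fluorescence, with a stated time of 48 h (a higher number here means that more compound is needed for the effect, a lower number that less compound is needed), compound 1 gives 10400 nM, compound 2 gives 10900 nM, and compound 3 gives 14300 nM. Compound 3 stands at the highest of the three numbers shown, yet its steps from both other members lie within the scatter: a 1.4-fold higher number from compound 1 to compound 3 (0.14 log units; within the scatter) and a 1.3-fold higher number from compound 2 to compound 3 (0.12 log units; within the scatter). The remaining step, a 1.0-fold higher number from compound 1 to compound 2 (0.02 log units; within the scatter), is likewise within the scatter.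

Compound 4 `CC(C)=CCC/C(C)=C/CC/C(C)=C/CSC[C@H](NC(=O)CCCCCN1CCN(C)CC1)C(=O)NC1CCCCCCC1` is the next member. cyclooctylamino in place of piperidin-1-yl on a carbonyl carbon All three measured steps bear on this change, as each alters the same amide end, and none of them moved the number beyond the scatter. A step beyond the scatter in this assay is therefore not expected; the expected step is a 1.2-fold lower number from compound 3 to compound 4 (0.08 log units; within the scatter). Compound 4 is estimated at 12000 nM in this assay, with an expected range from 6000 nM to 25000 nM.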

Compound 4, half-maximal effective concentration: 2500 nM
For compound 4 the middle estimate is 4.8-fold (0.68 log units) above the measured one; the whole stated range lies above it.
By their numbers in this assay, from the lowest: compound 4; then compounds 1, 2 and 3 (each within the scatter of the next).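

Among these compounds, at the amide end, cyclooctylamino is the first group to move the number in this assay beyond the scatter, with a 5.7-fold lower number from compound 3 to compound 4 (0.76 log units; beyond the scatter) against the piperidin-1-yl amide. The same direction holds among the amides that keep the amide hydrogen, with a 4.4-fold lower number from compound 2 to compound 4 (0.64 log units; beyond the scatter) and a 4.2-fold lower number from compound 1 to compound 4 (0.62 log units; beyond the scatter), so the result does not rest on the comparison with piperidin-1-yl alone. Nothing shown gives a reason why the eight-membered carbon ring separates compound 4 from compounds 1, 2 and 3.

As far as these compounds go, whether the lower number needs a ring of this size remains open, as cyclohexylamino and cycloheptylamino would test the range between cyclopentyl and cyclooctyl. An open-chain octylamino group would show whether the ring itself matters or the carbon count alone.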